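Piperazin-1-yl in place of piperidin-4-yl: compound 4

The source may hold more compounds than are shown below. What is called first, only, known or untested is meant among the compounds shown, and "the series" means these compounds.

In an ADME assay on microsomes from liver (Rattus norvegicus) for metabolic stability, read by LC-MS, with a stated time of 10 min, tested at 0.5 uM (on this read-out higher numbers stand for a more stable compound and lower numbers for a less stable compound), compound 1 (`c1ccc2c(c1)CN[C@@H](CN(CCC1CCNCC1)[C@H]1CCCc3cccnc31)C2`) gives 17% as the middle of three measured numbers. Compound 3 (`CN1CCN(CCCN(C[C@H]2Cc3ccccc3CN2C)[C@H]2CCCc3cccnc32)CC1`) lies lower at 2% and compound 2 (`c1cnc2c(c1)CCC[C@@H]2N(CCCN1CCNCC1)Cc1cc2ccccc2cn1`) higher at 59% with both gaps beyond the scatter. Compound 4 (`c1ccc2c(c1)CN[C@@H](CN(CCN1CCNCC1)[C@H]1CCCc3cccnc31)C2`) carries piperazin-1-yl in place of piperidin-4-yl on a saturated chain carbon, two bonds along the chain from an amine nitrogen. Among the compounds with values here, no measured pair isolates this change, so the expectation is loose. Compound 2 also carries piperazin-1-yl and stands at 59% as a weak hint upward, since it differs from compound 1 elsewhere as well. The expected change (a number 9 percentage points higher from compound 1 to compound 4 (within the scatter)) is upward but within the scatter. Compound 4 is estimated in this assay at 26% (expected range 8% to 50%).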

Compound 4, percent of the compound remaining: 62%
For compound 4 the middle estimate is 36 percentage points below the measured one; the whole stated range lies below it.
By their numbers in this assay, from the lowest: compound 3; then compound 1; then compounds 2 and 4 (each within the scatter of the next).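

In this assay, piperazin-1-yl in place of piperidin-4-yl on a saturated chain carbon, two bonds along the chain from an amine nitrogen, gives a number 45 percentage points higher from compound 1 to compound 4 (beyond the scatter) as a large step. Within the data shown here, this is the first pair that differs in one place, and it shows that the number responds strongly to this exchange with the core of compound 1 unchanged. Nothing measured here accounts for the step.

Still open, on these data alone, is whether morpholin-4-yl at this place would read closer to compound 1 or compound 4. Also open, as far as these compounds go, is whether the same exchange gives a step of similar size on other cores.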